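A Butyl Chain Replaces Fluorine on a Shared Core

A few compounds are considered here, and "the series" means these few. Any claim that something is new, unique, unknown or untested is made for them only; others in the source may bear on it.

Of the compounds shown here, three built on a shared core have been tested in a functional assay on K562 cells (Homo sapiens) for inhibition, read by MTT assay, with a stated time of 72 h; a lower number here means a stronger inhibitor, a higher number a weaker inhibitor. Compound 1 `O=C(O)/C=C/C(=O)c1ccc(Cl)c(Cl)c1` gives 23200 nM, compound 2 `CCCCCCCCCCCCc1ccc(C(=O)/C=C/C(=O)O)cc1` gives 4010 nM, and compound 3 `O=C(O)/C=C/C(=O)c1ccc(F)cc1` gives 16900 nM. Among these three numbers compound 3 holds the second highest. Its closest neighbour is compound 1, whose number is higher but only by a margin that lies within the scatter of repeated measurements, so the two cannot be ranked against each other. Compound 2, with its dodecyl chain, stands further away: its number is lower than that of compound 3 by a gap that exceeds the scatter.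

Compound 4 `CCCCc1ccc(C(=O)/C=C/C(=O)O)cc1` has not yet been measured in this assay. It differs from compound 3 in one place: butyl in place of fluoro on an aromatic carbon. A butyl chain is shorter than the dodecyl chain of compound 2, so compound 4 may be expected to land somewhere between compound 3 and compound 2. Expected is a downward step of a 1.9-fold lower number from compound 3 to compound 4 (0.27 log units; within the scatter), beyond the scatter but not reaching the lowest number seen so far. On that basis compound 4 is estimated to give 9000 nM, with a likely range from 4500 nM to 18000 nM.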

Compound 4, half-maximal inhibitory concentration: 4950 nM
Beside the measured number, compound 4's estimate is 1.8-fold (0.26 log units) above it; the range from low to high includes it.
By their numbers in this assay, from the lowest: compounds 2 and 4 (each within the scatter of the next); then compounds 3 and 1 (each within the scatter of the next).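

In this assay, the group on this aromatic carbon clearly matters: butyl in place of fluoro gives a 3.4-fold lower number from compound 3 to compound 4 (0.53 log units; beyond the scatter). This step lies beyond the scatter of repeated measurements. Going the other way along the chain tells a different story, since shortening the dodecyl chain to butyl gives a 1.2-fold higher number from compound 2 to compound 4 (0.09 log units; within the scatter) and leaves compound 2 and compound 4 impossible to rank against each other. Among the compounds shown, then, the butyl chain already matches what the much longer dodecyl chain achieves, and extra length brings no change that can be told from the scatter; the data at hand offer no measurement that explains why.

Going by these compounds, what happens with chains of intermediate length, such as hexyl or octyl, remains open, as does whether a branched group such as tert-butyl would behave like the straight butyl chain. Also unknown is how this same aromatic carbon would respond to an amine, a methoxy group or a butyl chain ending in a hydroxyl group.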